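This account rests on a few compounds, and the source may have more. Where it says the series, first, only, none or still open, it means among the compounds named here.

Three compounds share one core and differ only in the chain that hangs from an oxygen on an aromatic ring. In a physicochemical assay for solubility, read by spectrophotometry, using the shake flask method, with a stated time of 2 days, at pH 6.5 (on this read-out higher numbers stand for higher solubility and lower numbers for lower solubility), compound 2 `NCCOc1ccc2nc(-c3cn(-c4ccc(O)cc4)nn3)ccc2c1` gives 3.7 ug/mL, the lowest of the three numbers. Compound 1 `O=C(O)CCCOc1ccc2nc(-c3cn(-c4ccc(O)c(F)c4)nn3)ccc2c1` gives 19.2 ug/mL and compound 3 `O=C(O)COCCOc1ccc2nc(-c3cn(-c4ccc(O)c(F)c4)nn3)ccc2c1` gives 867 ug/mL. Among the compounds with values here, the one measured step, a 45-fold higher number from compound 1 to compound 3 (1.65 log units; beyond the scatter), concerns carboxymethoxy in place of carboxymethyl and does not touch the aminomethyl of compound 2, so no measured step bears directly on the change at hand. Compound 4 `Oc1ccc(-n2cc(-c3ccc4cc(OCC5CCCCO5)ccc4n3)nn2)cc1` differs from compound 2 by oxan-2-yl in place of aminomethyl on a saturated chain carbon bound to an oxygen on an aromatic ring. With nothing measured to lean on, the expectation rests on compound 2 alone and stays cautious. Compound 4 is expected to give about 2.5 ug/mL, within 0.4 ug/mL to 15 ug/mL. That amounts to an expected 1.5-fold lower number from compound 2 to compound 4 (0.17 log units; within the scatter).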

Compound 4, solubility: 3.4 ug/mL
The estimate for compound 4 lay 1.4-fold (0.13 log units) below the measured number; low and high end bracket the measured number.
By their numbers in this assay, from the lowest: compounds 4 and 2 (each within the scatter of the next); then compound 1; then compound 3.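

In this assay, oxan-2-yl in place of aminomethyl on a saturated chain carbon bound to an oxygen on an aromatic ring gives a 1.1-fold lower number from compound 2 to compound 4 (0.04 log units; within the scatter). So a larger group with a six-membered non-aromatic ring and no hydrogen-bond donor leaves the read-out within the scatter of the aminomethyl compound. Nothing measured here explains this result.

Going by these compounds, whether a hydroxyl group or a morpholin-4-yl group at this place would also stay within the scatter remains open. So does whether oxan-2-yl would give a similar step on the core of compound 1.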